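Demethylation steps in one cytotoxicity series

The source may report more compounds than this note shows. Statements on the series, on what has been measured and on what is new or still open speak of the compounds shown alone.

Compound 1 `COc1ccc(/C=C2\CCC/C(=C\c3cccc(OC)c3OC)C2=O)cc1` gives 18600 nM in a functional assay on MCF7 cells (Homo sapiens) for cytotoxicity, read by MTT assay, with a stated time of 72 h; a lower number here means a stronger inhibitor, a higher number a weaker inhibitor.
Compound 2 `COc1cccc(/C=C2\CCC/C(=C\c3ccc(O)cc3)C2=O)c1OC` gives > 20000 nM in this assay, which is a limit of the assay and not a number.
Compound 3 `COc1cc(/C=C2\CCC/C(=C\c3cccc(OC)c3OC)C2=O)ccc1O` gives 11600 nM in this assay.

Compound 4 `COc1cccc(/C=C2\CCC/C(=C\c3ccc(O)c(O)c3)C2=O)c1OC` has not yet been measured in this assay. It differs from compound 3 by hydrogen in place of methyl on an oxygen on an aromatic ring. The same change was already made once, from compound 1 to compound 2, where it reads (hydrogen in place of methyl on an oxygen on an aromatic ring); the place is the same in both cases. That measured step was an at least 1.0-fold higher number from compound 1 to compound 2 (0.03 log units; that floor lies within the scatter), though only a floor can be given, since compound 2 sits at the limit (the limit of > 20000 nM in this assay, at which 1 of the 3 values shown sits). The cores on which the change is made differ as 4-hydroxy-3-methoxyphenyl in place of 4-methoxyphenyl on a double-bonded chain carbon bound to a double-bonded ring carbon; that difference gave a 1.6-fold lower number from compound 1 to compound 3 (0.21 log units; within the scatter).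

From compound 3 to compound 4 the step is expected to be about a 1.3-fold higher number from compound 3 to compound 4 (0.11 log units; within the scatter), resting on the earlier step of an at least 1.0-fold higher number from compound 1 to compound 2 (0.03 log units; that floor lies within the scatter), which shows no gain from removing the methyl. For compound 4 the expected value in this assay is 15000 nM, with a likely range from 7000 nM to 35000 nM; a limit rather than a number is a real possibility.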

Compound 4, half-maximal inhibitory concentration: 4700 nM
Estimate against measurement, compound 4: 3.2-fold (0.50 log units) above, and the stated range ends above it.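

In this assay, the change from methoxy to hydroxy that turns 4-hydroxy-3-methoxyphenyl into 3,4-dihydroxyphenyl gives a 2.5-fold lower number from compound 3 to compound 4 (0.39 log units; beyond the scatter), and the 3,4-dihydroxyphenyl group also reads an at least 4.2-fold lower number from compound 2 to compound 4 (0.62 log units; beyond the scatter) and a 4.0-fold lower number from compound 1 to compound 4 (0.60 log units; beyond the scatter). The removal of the methyl thus lowers the number on the core of compound 3, but this does not show whether the size of the step depends on the core: the same change on two cores in this assay, an at least 1.0-fold higher number (0.03 log units; that floor lies within the scatter) from compound 1 to compound 2 and a 2.5-fold lower number (0.39 log units; beyond the scatter) from compound 3 to compound 4; the limit leaves it open whether they differ. Compound 2 gives a limit of the assay and not a number: the limit of > 20000 nM in this assay, at which 1 of the 4 values shown sits.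

Going by these compounds, the aryl group carrying the two methoxy groups is common to all four compounds, so it remains open whether the same change would read alike on that side of the shared core. Also open, on these data alone, is how an amine or a carboxylic acid in place of the hydroxy would read in this assay.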